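A few compounds are considered here, and "the series" means these few. Any claim that something is new, unique, unknown or untested is made for them only; others in the source may bear on it.

Compound 1 `Clc1ccc(/C=N/Nc2nc3ccccc3s2)cc1` in a functional assay on HL-60 cells (Homo sapiens) for cytotoxicity, read by MTT assay, with a stated time of 72 h; a lower number here means a stronger inhibitor, a higher number a weaker inhibitor: > 17300 nM
Compound 2 `CN(C)c1ccc(/C=N/Nc2nc3ccccc3s2)cc1` in this assay: > 16800 nM
Compound 3 `Clc1ccc(/C=N/Nc2nc3ccccc3s2)c(Cl)c1` in this assay: > 15500 nM

Every value in this assay is a limit of the assay rather than a number. Compound 2 stands at such a limit, > 16800 nM, with nothing more readable about it. The two measured steps, a step that the two limits leave unreadable from compound 1 to compound 2 and a step that the two limits leave unreadable from compound 1 to compound 3, are both unreadable for the same reason, so neither bears a usable size on the change to compound 4 `Brc1ccc(/C=N/Nc2nc3ccccc3s2)cc1`, which differs from compound 2 by bromo in place of dimethylamino on an aromatic carbon. With only limits and unreadable steps in hand, compound 4 is expected to give a step that the limit leaves unreadable from compound 2 to compound 4 that cannot be distinguished from none, most likely as another limit. Compound 4 is therefore estimated at 20000 nM, with a range from 7000 nM to 80000 nM.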

Compound 4, half-maximal inhibitory concentration: > 15000 nM
Compound 4 was reported as a limit; the forecaster's own chance of this, stated with the estimate: 85%; the middle value does not contradict the limit.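

Compound 4, like compound 1 and compound 2, is reported only as a limit in this assay, so neither new step to compound 4 can be read. The compounds shown leave open how strongly any of them inhibits.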